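The compounds below may be only part of what the source reports. "The series", "measured", "known", "first", "only" and "open" are said of these compounds alone.

Measured compounds:
- compound 1, `O=C(O)c1cccc(CCCCCCC(=O)c2ncc(-c3ccccn3)o2)c1`: > 600 nM
- compound 2, `O=C(CCCCCCc1ccccc1Cl)c1ncc(-c2ccccn2)o1`: 1.9 nM
- compound 3, `COc1ccc(CCCCCCC(=O)c2ncc(-c3ccccn3)o2)cc1`: 6.2 nM

In an assay for inhibition of Fatty-acid amide hydrolase 1 (Rattus norvegicus) (a lower number here means a stronger inhibitor, a higher number a weaker inhibitor), compound 3 gives the highest of the two plain numbers shown. Compound 2 sits nearest, separated from it by the step of a 3.3-fold higher number from compound 2 to compound 3 (0.51 log units; beyond the scatter). Compound 1 gives only a limit in this assay, and the entry the limit of > 600 nM in this assay, at which 1 of the 3 values shown sits, marks it as such.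

The unmeasured compound 4, `Nc1cccc(CCCCCCC(=O)c2ncc(-c3ccccn3)o2)c1`, differs from compound 3 by 3-aminophenyl in place of 4-methoxyphenyl on a saturated chain carbon, six bonds along the chain from a carbonyl carbon. Within the data shown here, two measured steps bear on this place on the chain. The step of an at least 96-fold lower number from compound 1 to compound 3 (1.98 log units; beyond the scatter) shows that replacing 3-carboxyphenyl with 4-methoxyphenyl there shifts the number greatly, while the step of a 3.3-fold higher number from compound 2 to compound 3 (0.51 log units; beyond the scatter) shows a smaller shift between 2-chlorophenyl and 4-methoxyphenyl. The entering 3-aminophenyl carries one hydrogen-bond donor and one hydrogen-bond acceptor and no net charge. A modest step, weaker than compound 3, is expected rather than a large one. For compound 4 the expected step is a 2.4-fold higher number from compound 3 to compound 4 (0.38 log units; beyond the scatter). Compound 4 is estimated at 15 nM, with a range from 4 nM to 60 nM.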

Compound 4, inhibition constant: 30 nM
For compound 4 the middle estimate is 2.0-fold (0.30 log units) below the measured one, and the stated range covers the measured number.
By their numbers in this assay, from the lowest: compound 2; then compound 3; then compound 4. At a limit, above all of these: compound 1.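

In this assay, 3-aminophenyl at this place on the chain does worse than both earlier rings that gave plain numbers: the change from 4-methoxyphenyl gives a 4.8-fold higher number from compound 3 to compound 4 (0.68 log units; beyond the scatter), and the change from 2-chlorophenyl gives a 16-fold higher number from compound 2 to compound 4 (1.20 log units; beyond the scatter). Amino in place of carboxy on the same aromatic carbon gives an at least 20-fold lower number from compound 1 to compound 4 (1.30 log units; beyond the scatter), so a substituent at that ring place does not by itself bring the full loss seen with 3-carboxyphenyl. Compound 1 stands at a limit, so the true size of that step is unknown: the limit of > 600 nM in this assay, at which 1 of the 4 values shown sits.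

Compound 4 changes both the group on the ring and its place on the ring relative to compound 3, so these two changes cannot be told apart. A 4-aminophenyl or a 3-methoxyphenyl at this place on the chain would separate them.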